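The source may report more compounds than this note shows. Statements on the series, on what has been measured and on what is new or still open speak of the compounds shown alone.

Three compounds share one core and differ only in the group on the aromatic carbon next to the ring nitrogen. Compound 1 `Cc1ccc(Nc2nc(C(F)(F)F)ccc2CNC(=O)C(C)c2ccc(NS(C)(=O)=O)c(F)c2)cc1C` carries a (3,4-dimethylphenyl)amino group there, and in a functional assay on CHO-K1 cells for antagonist activity at transient receptor potential cation channel subfamily V member 1 (Homo sapiens), read by FLIPR (a lower number here means a stronger inhibitor, a higher number a weaker inhibitor), compound 1 gives 39.3 nM. Compound 2 `CCCCN(C)c1nc(C(F)(F)F)ccc1CNC(=O)C(C)c1ccc(NS(C)(=O)=O)c(F)c1` carries butyl(methyl)amino instead, and in this assay compound 2 gives 0.8 nM. Compound 3 `CC(C(=O)NCc1ccc(C(F)(F)F)nc1N(C)c1ccccc1)c1ccc(NS(C)(=O)=O)c(F)c1` carries methyl(phenyl)amino, and in this assay compound 3 gives 0.9 nM. Compound 3 thus has the second highest of the three numbers; its nearest neighbour is compound 2, while compound 1 is the furthest away, as the step of a 44-fold lower number from compound 1 to compound 3 (1.64 log units; beyond the scatter) shows.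

Compound 4 `CC(C(=O)NCc1ccc(C(F)(F)F)nc1N1CCC(O)CC1)c1ccc(NS(C)(=O)=O)c(F)c1` is the next step from compound 3: 4-hydroxypiperidin-1-yl in place of methyl(phenyl)amino on an aromatic carbon. Going by the values given here, two measured steps bear on this. Replacing the (3,4-dimethylphenyl)amino group by a smaller amine gave a 49-fold lower number from compound 1 to compound 2 (1.69 log units; beyond the scatter) and a 44-fold lower number from compound 1 to compound 3 (1.64 log units; beyond the scatter), both large. Exchanging the two smaller amines against each other gave a 1.1-fold higher number from compound 2 to compound 3 (0.05 log units; within the scatter), which changes little. Among the compounds with values here, no measured compound carries a ring amine with a hydroxyl, so the 4-hydroxypiperidin-1-yl group has no direct precedent here. An expectation of a small change, within the scatter or only slightly weaker, is therefore a 1.7-fold higher number from compound 3 to compound 4 (0.22 log units; within the scatter). Compound 4 is estimated at 1.5 nM, between 0.5 nM and 6 nM.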

Compound 4, inhibition constant: "not active" (no number reported)
No number was reported for compound 4; no gap can be computed for the estimate.
By their numbers in this assay, from the lowest: compounds 2 and 3 (each within the scatter of the next); then compound 1.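

In this assay, going by these compounds alone, compound 4 is reported only as "not active", without a number, so no step from compound 3 or from compounds 1 and 2 can be read. The compounds shown leave open whether the hydroxyl, the non-aromatic ring, or both separate compound 4 from compound 3. Nothing available here offers an explanation for this result.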